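A few compounds are considered here, and "the series" means these few. Any claim that something is new, unique, unknown or untested is made for them only; others in the source may bear on it.

Measured so far:
compound 1 `O=C(CN1C(=O)/C(=C/c2ccc(-c3ccc(Cl)cc3)o2)SC1=S)NCc1ccc(C(F)(F)F)cc1`: in a functional assay on REH cells (Homo sapiens) for cytotoxicity, read by MTT assay, with a stated time of 72 h (a lower number here means a stronger inhibitor, a higher number a weaker inhibitor), compound 1 gives 170000 nM
compound 2 `O=C(CN1C(=O)/C(=C/c2ccc(-c3ccc(Cl)cc3)o2)SC1=S)NCc1ccccc1Cl`: in this assay compound 2 gives 70000 nM

Among the compounds with values here, compound 2 holds the lower of the two numbers; the only measured step is a 2.4-fold lower number from compound 1 to compound 2 (0.39 log units; beyond the scatter). Compound 3 `CCCCCCNC(=O)CN1C(=O)/C(=C/c2ccc(-c3ccc(Cl)cc3)o2)SC1=S` carries the change (pentyl in place of 2-chlorophenyl on a saturated chain carbon bound to an amide-type nitrogen). Within the data shown here, no measured step exchanges an aromatic ring for a chain, so the step from compound 1 to compound 2 bears on it only loosely, as a sign that this position tolerates variation. The step into compound 3 in this assay is therefore expected to be small, without clear direction, possibly none beyond the scatter. Compound 3 is estimated at 90000 nM, between 30000 nM and 250000 nM, the expected step being a 1.3-fold higher number from compound 2 to compound 3 (0.11 log units; within the scatter).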

Compound 3, half-maximal inhibitory concentration: 55000 nM
For compound 3 the middle estimate is 1.6-fold (0.21 log units) above the measured one; the range from low to high includes it.
By their numbers in this assay, from the lowest: compounds 3 and 2 (each within the scatter of the next); then compound 1.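

In this assay, a ringless chain stands level with the 2-chlorophenyl group at this position, with a 1.3-fold lower number from compound 2 to compound 3 (0.10 log units; within the scatter) here, so an aromatic ring on this side is not required to hold the value. The 4-(trifluoromethyl)phenyl group of compound 1 stays apart from both, with a 3.1-fold lower number from compound 1 to compound 3 (0.49 log units; beyond the scatter) for the exchange to pentyl. Nothing available explains either step.

Open, as far as these compounds go, is whether a longer chain, or an amine or carboxylic acid on the chain, would move the number beyond the scatter of compound 3. Changes to the shared core also remain untested here.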